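The source may report more compounds than this note shows. Statements on the series, on what has been measured and on what is new or still open speak of the compounds shown alone.

Of the compounds shown here, two have been measured in an assay on cell membranes for displacement of a labelled ligand from proteinase-activated receptor 1 (Homo sapiens), read by scintillation counting, with a stated time of 60 min; on this read-out lower numbers stand for stronger inhibition and higher numbers for weaker inhibition. Compound 1 `CC(=O)OC1C[C@@H]2CCCC[C@@H]2[C@H]1/C=C/c1ccc(-c2cccc(F)c2)cn1` gives 67 nM, and compound 2 `CC(=O)NC1C[C@@H]2CCCC[C@@H]2[C@H]1/C=C/c1ccc(-c2cccc(F)c2)cn1` gives 53 nM. The step of a 1.3-fold lower number from compound 1 to compound 2 (0.10 log units; within the scatter) leaves the two numbers within the scatter of each other, so neither can be called stronger. Compound 3 `CN(C1C[C@@H]2CCCC[C@@H]2[C@H]1/C=C/c1ccc(-c2cccc(F)c2)cn1)S(C)(=O)=O` differs from compound 2 by methyl(methylsulfonyl)amino in place of acetamido on a saturated ring carbon. Within the data shown here, no measured step covers this change; the only related step, a 1.3-fold lower number from compound 1 to compound 2 (0.10 log units; within the scatter), exchanged the same group and was small. A step of a 1.9-fold higher number from compound 2 to compound 3 (0.28 log units; within the scatter) is therefore expected. Compound 3 is estimated at 100 nM, between 25 nM and 400 nM.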

Compound 3, half-maximal inhibitory concentration: 1.3 nM
For compound 3 the middle estimate is 77-fold (1.89 log units) above the measured one, outside the stated range (below it).
By their numbers in this assay, from the lowest: compound 3; then compounds 2 and 1 (each within the scatter of the next).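

This ring carbon proved sensitive to the group it carries, which the exchange between acetoxy and acetamido, a step within the scatter, gave no sign of. Methyl(methylsulfonyl)amino brings a 41-fold lower number from compound 2 to compound 3 (1.61 log units; beyond the scatter) and a 52-fold lower number from compound 1 to compound 3 (1.71 log units; beyond the scatter), so both earlier groups are left far behind. Nothing measured here accounts for so large a change.

Going by these compounds, it remains open whether the sulfonyl or the methyl on nitrogen matters more. A methylsulfonylamino group without that methyl, or an N-methylacetamido group, would separate the two.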